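The source may hold more compounds than are shown below. What is called first, only, known or untested is meant among the compounds shown, and "the series" means these compounds.

Measured in an ADME assay on CHO cells (Cricetulus griseus) for cytotoxicity, read by MTT assay; a lower number here means that less compound is tolerated, a higher number that more compound is tolerated:
- compound 1 `CN1CCN(CC2CCN(c3nccc4[nH]c(-c5ccc(F)c(F)c5)nc34)CC2)CC1`: 7400 nM
- compound 2 `CN1CCN(CC2CCN(c3nccc4[nH]c(-c5cccc(OC(F)(F)F)c5)nc34)CC2)CC1`: 950 nM

Compound 2, at 950 nM, has the lower of the two numbers, so it is the less tolerated of the pair. Compound 3 `CN1CCN(CC2CCN(c3nccc4[nH]c(-c5ccc(F)c(Cl)c5)nc34)CC2)CC1` carries 3-chloro-4-fluorophenyl in place of 3-(trifluoromethoxy)phenyl on an aromatic carbon. For the measured compounds named here, only one measured step bears on this change: a 7.8-fold lower number from compound 1 to compound 2 (0.89 log units; beyond the scatter), which brought in that same 3-(trifluoromethoxy)phenyl. Removing the group should undo much of that step, so a somewhat smaller move towards a higher number is expected in this assay: a 3.7-fold higher number from compound 2 to compound 3 (0.57 log units; beyond the scatter). Compound 3 is estimated at 3500 nM, with an expected range of 1400 nM to 9000 nM.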

Compound 3, half-maximal cytotoxic concentration: 850 nM
The estimate for compound 3 lay 4.1-fold (0.61 log units) above the measured number; measured number outside the range, below it.
By their numbers in this assay, from the lowest: compounds 3 and 2 (each within the scatter of the next); then compound 1.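

In this assay the earlier step tied the lower number to 3-(trifluoromethoxy)phenyl, yet 3-chloro-4-fluorophenyl in its place gives a 1.1-fold lower number from compound 2 to compound 3 (0.05 log units; within the scatter) and so cannot be told apart from it. Chloro in place of fluoro alone gives an 8.7-fold lower number from compound 1 to compound 3 (0.94 log units; beyond the scatter) and so shows that this single swap on the phenyl ring is enough, without any trifluoromethoxy group. No measured evidence offers a reason for this. Going by these compounds, it remains open whether fluoro itself favours the higher number of compound 1, or whether a hydrogen, methyl or nitrile in the place of that chloro would do the same.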